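This account rests on a few compounds, and the source may have more. Where it says the series, first, only, none or still open, it means among the compounds named here.

Compound 1 `COc1ccc2cc(C(C)(O)CCN(C)C)ccc2c1` with 41 nM in an assay for displacement of a labelled ligand from Sigma non-opioid intracellular receptor 1 (Cavia porcellus), read by scintillation counting, with a stated time of 120 min; on this read-out higher numbers stand for weaker inhibition and lower numbers for stronger inhibition; compound 2 `COc1ccc2cc([C@](C)(O)CCN(C)C)ccc2c1` with 51 nM.

Compound 2 stands highest of the two numbers in this assay, its nearest neighbour being compound 1, with a 1.2-fold higher number from compound 1 to compound 2 (0.09 log units; within the scatter). That step is the only one bearing on the move to compound 3 `COc1ccc2cc([C@@](C)(O)CCN(C)C)ccc2c1`, whose change is the two compounds have the same atoms and bonds and differ only in configuration as drawn: 1 of 1 stereo elements differ; a stereocentre at a saturated chain carbon is drawn R in compound 2 and S in compound 3. It is small, in keeping with the fact that one of compounds 1 and 2 is drawn with a defined configuration and the other without, at the place where they differ. Compound 3 is therefore expected to sit close to both measured compounds, with a 1.5-fold lower number from compound 2 to compound 3 (0.18 log units; within the scatter) not exceeding the scatter. The estimate for compound 3 is 34 nM, ranging from 15 nM to 80 nM.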

Compound 3, inhibition constant: 25 nM
The estimate for compound 3 lay 1.4-fold (0.13 log units) above the measured number; measured number inside the range.
By their numbers in this assay, from the lowest: compounds 3, 1 and 2 (each within the scatter of the next, the first and the last beyond it).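

In this assay the R and S drawings of the stereocentre at a saturated chain carbon are now separated by a 2.0-fold lower number from compound 2 to compound 3 (0.31 log units; beyond the scatter), a modest step that can be put down to configuration alone: the fact that compounds 2 and 3 differ only in the configuration as drawn. Set against the drawing without a configuration, the S drawing gives a 1.6-fold lower number from compound 1 to compound 3 (0.21 log units; within the scatter) and so stays within the scatter: the fact that one of compounds 1 and 3 is drawn with a defined configuration and the other without, at the place where they differ. Going by these compounds, whether the gap between the two configurations would persist with a longer chain, or with a piperidine in place of the dimethylamino group, remains open.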